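Pendant aryl exchange on a shared core: expected cytotoxicity

This account rests on a few compounds, and the source may have more. Where it says the series, first, only, none or still open, it means among the compounds named here.

compound 1 `Cc1nc2c3ccccc3ccc2c2nc3c(ccc4ccccc43)c(-c3cccnc3)c12`: 3860 nM
compound 2 `Cc1nc2c3ccccc3ccc2c2nc3c(ccc4ccccc43)c(-c3ccccc3S)c12`: 3190 nM
compound 3 `Cc1nc2c3ccccc3ccc2c2nc3c(ccc4ccccc43)c(-c3ccc(O)cc3)c12`: 4630 nM

All three were tested in a functional assay on HeLa cells (Homo sapiens) for cytotoxicity, read by MTT assay, with a stated time of 48 h; a lower number here means a stronger inhibitor, a higher number a weaker inhibitor. Compound 1 stands second highest of the three numbers: its nearest neighbour is compound 3, a 1.2-fold higher number from compound 1 to compound 3 (0.08 log units; within the scatter), and its furthest is compound 2, a 1.2-fold lower number from compound 1 to compound 2 (0.08 log units; within the scatter), so both gaps fall within the scatter. Compound 4 `Cc1ccc(-c2c3ccc4ccccc4c3nc3c2c(C)nc2c4ccccc4ccc32)cc1` differs from compound 1 by 4-methylphenyl in place of pyridin-3-yl on an aromatic carbon. The two measured steps that leave compound 1 each exchange the same pendant aryl group, and neither of them moved the number beyond the scatter, so they are the ones that bear on this change. One therefore expects no step beyond the scatter, a 1.0-fold higher number from compound 1 to compound 4 (0.00 log units; within the scatter). Compound 4 is estimated at 3900 nM, with a range from 2000 nM to 7600 nM.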

Compound 4, half-maximal inhibitory concentration: 72200 nM
For compound 4 the middle estimate is 19-fold (1.27 log units) below the measured one; measured number above the stated range.
By their numbers in this assay, from the lowest: compounds 2, 1 and 3 (each within the scatter of the next); then compound 4.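

The position is not indifferent to the pendant aryl group: a 19-fold higher number from compound 1 to compound 4 (1.27 log units; beyond the scatter) is the change to 4-methylphenyl, and a 23-fold higher number from compound 2 to compound 4 (1.35 log units; beyond the scatter) is the same change starting from the 2-sulfanylphenyl group. A single exchange of methyl for hydroxy on the pendant ring is enough, giving a 16-fold higher number from compound 3 to compound 4 (1.19 log units; beyond the scatter). Of the four compounds, only compound 4 carries a pendant ring with substituents of carbon only, and the three with a hetero atom there stay within the scatter of one another. Nothing measured here accounts for this gap. As far as these compounds go, whether 4-aminophenyl or unsubstituted phenyl would stay with compound 3 or go with compound 4 remains open.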